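Cytotoxicity notes: acetylthiophenyl replaces acetamidophenyl on the ester

The source may report more compounds than this note shows. Statements on the series, on what has been measured and on what is new or still open speak of the compounds shown alone.

The series is built on the core of compound 3 `CCOC(=O)CCCCCOc1cccc(CN(C(=O)c2ccc(-c3cccc(NC(C)=O)c3)cc2)C(C)C)c1`, the ethyl ester of compound 1 `CC(=O)Nc1cccc(-c2ccc(C(=O)N(Cc3cccc(OCCCCCC(=O)O)c3)C(C)C)cc2)c1`; compound 2 `COc1cc(F)cc(-c2ccc(C(=O)N(Cc3cccc(OCCCCCC(=O)O)c3)C(C)C)cc2)c1` carries 3-fluoro-5-methoxyphenyl in place of 3-acetamidophenyl on an aromatic carbon. In an ADME assay on BJ cells (Homo sapiens) for cytotoxicity, read by CellTiter-Glo and resazurin assay, with a stated time of 72 h (a higher number here means that more compound is needed for the effect, a lower number that less compound is needed), compound 1 gives only a limit, > 26000 nM. Compound 2 also gives only a limit in this assay, > 26000 nM. Compound 3 likewise gives only a limit in this assay, > 26000 nM. Compound 3 therefore stands where every measured compound stands, at the limit of > 26000 nM in this assay, at which 3 of the 3 values shown sit.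

The two measured steps, a step that the two limits leave unreadable from compound 1 to compound 2 and a step that the two limits leave unreadable from compound 1 to compound 3, remain unreadable due to the limit of > 26000 nM in this assay, at which 3 of the 3 values shown sit: neither the ester nor the aryl swap can be sized.

Compound 4 `CCOC(=O)CCCCCOc1cccc(CN(C(=O)c2ccc(-c3ccc(C(C)=O)s3)cc2)C(C)C)c1` keeps the ethyl ester of compound 3 and changes the distal aryl: 5-acetylthiophen-2-yl in place of 3-acetamidophenyl on an aromatic carbon.

Among the measured compounds shown here, both measured steps bear on compound 4 only in that they show no compound yet leaving the limit; no readable step in either direction exists. Compound 4 is expected to sit at the limit as well, so the step that the limit leaves unreadable from compound 3 to compound 4 is estimated as none beyond the scatter. Compound 4 is estimated at 35000 nM, with a range from 15000 nM to 100000 nM.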

Compound 4, half-maximal effective concentration: > 26000 nM
Compound 4 ended at the assay's limit; the forecaster's own chance of this, stated with the estimate: 75%; the middle value is on the limit's open side.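

No step from compound 3 to compound 4 can be read, and swapping 3-acetamidophenyl for 5-acetylthiophen-2-yl cannot be sized, because the result gives no number for either compound: the limit of > 26000 nM in this assay, at which 4 of the 4 values shown sit.

The compounds shown leave open whether any change to the distal aryl or the ester brings a readable value in this assay.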